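The source may hold more compounds than are shown below. What is called first, only, known or untested is meant among the compounds shown, and "the series" means these compounds.

Of the compounds shown here, three have so far been tested in an ADME assay on cells (Homo sapiens) for cytotoxicity; on this read-out lower numbers stand for higher toxicity in this test and higher numbers for lower toxicity in this test. Compound 1 `CCCc1nc(-c2ccc(OCCC(C)CCN3CCN(c4ccncc4)C3=O)cc2)no1` gives > 12500 nM, which is a limit of the assay rather than a number. Compound 2 `O=C1N(CCC(CCOc2ccc(-c3ccc(Cl)cc3)cc2)Cc2ccccc2)CCN1c1ccncc1` gives > 10000 nM, again only a limit. Compound 3 `O=C1N(Cc2cccc(COc3ccc(-c4ccc(Cl)cc4)cc3)n2)CCN1c1ccncc1` gives > 25000 nM, also a limit. Compound 2 therefore stands at a limit of this assay, as do the two others; no measured number is available for any of them. Compound 4 `O=C1N(CCC(CCOc2ccc(-c3ccc(Cl)cc3)cc2)c2ccccc2)CCN1c1ccncc1` has not yet been measured; it differs from compound 2 by phenyl in place of benzyl on a saturated chain carbon bound to two saturated chain carbons. For the measured compounds named here, no step between measured compounds is known here, so no size of step can be drawn from the data. The expected step from compound 2 to compound 4 is a step that the limit leaves unreadable from compound 2 to compound 4, nothing beyond the usual scatter. Compound 4 is expected to give 12000 nM, within a range from 5000 nM to 30000 nM.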

Compound 4, half-maximal cytotoxic concentration: > 25000 nM
Compound 4 gave a limit, no number; the forecaster's own chance of this, stated with the estimate: 80%; at least 2.0-fold (0.31 log units) between middle value and limit.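

Compound 2 and compound 4 each give only a limit in this assay, so the change from benzyl to phenyl cannot be read as a step. The compounds shown leave open at what concentration any of them becomes toxic to cells.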